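A few compounds are considered here, and "the series" means these few. Any claim that something is new, unique, unknown or untested is made for them only; others in the source may bear on it.

Measured compounds and their values in an assay on SH-SY5Y cells for inhibition of Voltage-dependent N-type calcium channel subunit alpha-1B (Homo sapiens), read by FLIPR and calcium flux, with stated times of 600 s and 300 s, in the presence of a further agent that is not named here; a lower number here means a stronger inhibitor, a higher number a weaker inhibitor:

- compound 1, `NCCCOc1ccc(CNc2nc3ccc(Oc4cccc(C(F)(F)F)c4)cc3s2)cc1`: 144000 nM
- compound 2, `CN(Cc1ccc(OCCCNC(=N)N)cc1)c1nc2ccc(Oc3ccccc3)cc2s1`: 113000 nM
- compound 3, `CN(Cc1ccc(OCCCN)cc1)c1nc2ccc(Oc3ccccc3)cc2s1`: 49000 nM

Compound 2 stands second highest of the three numbers in this assay. Its nearest neighbour is compound 1, whose value lies within the scatter of that of compound 2; the furthest is compound 3, reached by the step of a 2.3-fold lower number from compound 2 to compound 3 (0.36 log units; beyond the scatter), which replaces the guanidine tail with a primary amine.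

The unmeasured compound 4, `CN(Cc1ccc(OCCCNC(=N)N)cc1)c1nc2ccc(Oc3ccc(C#N)cc3)cc2s1`, differs from compound 2 by cyano in place of hydrogen on an aromatic carbon. No measured step touches this part of the molecule: the one listed step, from compound 2 to compound 3, changes the amine nitrogen of the side chain, and compound 1 differs from compound 2 in more than one place, so it yields no isolated step for the phenoxy ring. For the measured compounds named here, the only guidance is that all three measured values sit within a narrow band in this assay, and the step from compound 2 to compound 3, though beyond the scatter, is modest.

On that basis the step of a 1.1-fold lower number from compound 2 to compound 4 (0.05 log units; within the scatter) is expected to be small, with no clear direction beyond the scatter. For compound 4 the estimated value in this assay is 100000 nM, with a range from 40000 nM to 250000 nM.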

Compound 4, half-maximal inhibitory concentration: 143000 nM
Beside the measured number, compound 4's estimate is 1.4-fold (0.16 log units) below it, within the range that was stated.
By their numbers in this assay, from the lowest: compound 3; then compounds 2, 4 and 1 (each within the scatter of the next).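

In this assay, for the compounds shown here, the change from phenoxy to 4-cyanophenoxy gives the first isolated reading on this ring: a 1.3-fold higher number from compound 2 to compound 4 (0.10 log units; within the scatter). Going by these compounds alone, with the guanidine tail in place, adding cyano on this aromatic carbon therefore gives no separation from the hydrogen compound, whereas the side-chain change remains the only single-place step beyond the scatter, a 2.3-fold lower number from compound 2 to compound 3 (0.36 log units; beyond the scatter). No supporting measurement bears on this result, so the reading stays a plain comparison of the two numbers.

The compounds shown leave open whether a different group at the same place, such as an amine, a carboxylic acid or a longer chain ending in a nitrile, would move the number beyond the scatter, since cyano is the only substituent on this ring with a single-place comparison. They also leave open whether cyano would give the same small step on the primary amine tail of compound 3, which stands at 49000 nM, as a single reading on the guanidine series cannot show whether the two changes act independently.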